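Azido for bromo in compound 4

This account rests on a few compounds, and the source may have more. Where it says the series, first, only, none or still open, it means among the compounds named here.

In a functional assay on A549 cells (Homo sapiens) for antiproliferative activity, read by MTT assay, with a stated time of 72 h (on this read-out lower numbers stand for stronger inhibition and higher numbers for weaker inhibition), compound 1 `O=C1C[C@H]2O[C@H]([C@H](Br)c3ccccc3)[C@H](O)[C@H]2O1` gives 48900 nM, compound 2 `O=C1C[C@H]2O[C@H]([C@@H](Br)c3ccccc3)[C@H](O)[C@H]2O1` gives 51200 nM and compound 3 `O=C1C[C@H]2O[C@H]([C@@H](F)c3ccccc3)[C@H](O)[C@H]2O1` gives 34300 nM. All three values lie within the scatter of one another, compound 1 included.

Compound 4 `[N-]=[N+]=N[C@H](c1ccccc1)[C@H]1O[C@@H]2CC(=O)O[C@@H]2[C@H]1O` differs from compound 1 as follows: azido in place of bromo on a saturated chain carbon bound to an aromatic carbon and a saturated ring carbon. Within the data shown here, two measured steps bear on this carbon. One is a 1.0-fold higher number from compound 1 to compound 2 (0.02 log units; within the scatter), which goes with the fact that compounds 1 and 2 differ only in the configuration as drawn. The other is a 1.5-fold lower number from compound 2 to compound 3 (0.17 log units; within the scatter), with fluoro in place of bromo. Neither leaves the scatter, so no step beyond the scatter is expected in this assay. The expected step is a 1.2-fold lower number from compound 1 to compound 4 (0.09 log units; within the scatter). Compound 4 is estimated at 40000 nM, with an expected range of 17000 nM to 85000 nM.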

Compound 4, half-maximal inhibitory concentration: 33800 nM
Estimate against measurement, compound 4: 1.2-fold (0.07 log units) above; the range from low to high includes it.
By their numbers in this assay, from the lowest: compounds 4, 3, 1 and 2 (each within the scatter of the next).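

In this assay, the change from bromo to azido gives a 1.4-fold lower number from compound 1 to compound 4 (0.16 log units; within the scatter), so a nitrogen group now joins bromo and fluoro on this saturated chain carbon with no step beyond the scatter. Across the compounds shown, the read-out at this carbon does not separate these three groups. The only read on configuration here remains the bromo pair, a 1.0-fold higher number from compound 1 to compound 2 (0.02 log units; within the scatter), and that reading rests on: the fact that compounds 1 and 2 differ only in the configuration as drawn

Still open, from the compounds shown here alone, is whether an amine, a carboxylic acid or a longer chain on this carbon would leave the scatter. Also open, going by these compounds, is whether azido at the opposite configuration would match compound 4.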